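Swapping the Aryl Ketone on a Shared Core

The compounds below may be only part of what the source reports. "The series", "measured", "known", "first", "only" and "open" are said of these compounds alone.

Compound 3 `COc1cc(-c2nnc3n2NC(c2ccco2)C(C(=O)c2cccc4ccccc24)S3)cc(OC)c1OC` carries a (naphthalen-1-yl)carbonyl on a saturated ring carbon. In a functional assay on PC-3 cells (Homo sapiens) for cytotoxicity, read by MTT assay, with a stated time of 48 h (on this read-out lower numbers stand for stronger inhibition and higher numbers for weaker inhibition), compound 3 gives > 100000 nM, which is a limit of the assay rather than a number; it sits at the limit of > 100000 nM in this assay, at which 1 of the 3 values shown sits. Compound 1 `COc1cc(-c2nnc3n2NC(c2ccco2)C(C(=O)c2cccs2)S3)cc(OC)c1OC` gives 46200 nM in this assay, and compound 2 `COc1cc(-c2nnc3n2NC(c2ccco2)C(C(=O)c2ccccc2)S3)cc(OC)c1OC` gives 64300 nM. The change to compound 4 `COc1cc(-c2nnc3n2NC(c2ccco2)C(C(=O)c2ccc([N+](=O)[O-])cc2)S3)cc(OC)c1OC` is 4-nitrophenyl in place of naphthalen-1-yl on a carbonyl carbon. The measured steps on a carbonyl carbon are an at least 2.1-fold higher number from compound 1 to compound 3 (0.33 log units; beyond the scatter) and an at least 1.5-fold higher number from compound 2 to compound 3 (0.19 log units; that floor lies within the scatter): in each, moving from a single aromatic ring to the naphthalene raised the number. With a single ring entering again, a lower number is expected, so a step of roughly an at least 1.4-fold lower number from compound 3 to compound 4 (0.15 log units; that floor lies within the scatter) is expected. Compound 4 is therefore estimated at 70000 nM, within 30000 nM to 200000 nM.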

Compound 4, half-maximal inhibitory concentration: 27900 nM
Compound 4: the middle estimate sits 2.5-fold (0.40 log units) above what was measured; measured number outside the range, below it.
By their numbers in this assay, from the lowest: compounds 4, 1 and 2 (each within the scatter of the next, the first and the last beyond it). At a limit, above all of these: compound 3.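

In this assay, a group on the phenyl ring on this carbonyl carbon turns out to matter: nitro in place of hydrogen gives a 2.3-fold lower number from compound 2 to compound 4 (0.36 log units; beyond the scatter), whereas the earlier swap between single rings stayed within the scatter. Against thiophen-2-yl, the 4-nitrophenyl group gives a 1.7-fold lower number from compound 1 to compound 4 (0.22 log units; within the scatter), so compound 1 and compound 4 cannot be ranked, while against naphthalen-1-yl it gives an at least 3.5-fold lower number from compound 3 to compound 4 (0.55 log units; beyond the scatter). That last step is only a floor, as compound 3 stands at a limit of the assay: the limit of > 100000 nM in this assay, at which 1 of the 4 values shown sits.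

Still open, from the compounds shown here alone, is whether the lower number belongs to nitro itself or would appear with another group at that spot, such as an amine or a carboxylic acid.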